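Cyclobutyl ether on the shared core: an estimate

The source may report more compounds than this note shows. Statements on the series, on what has been measured and on what is new or still open speak of the compounds shown alone.

Measured so far:
- Compound 1, `CCCCOc1cc(CCc2nc(C)c(CC)s2)nc(NCc2cc(Cl)cc(NC(=O)OC(C)C)c2)c1`: 16 nM
- Compound 2, `CCc1sc(CCc2cc(OC(CC)CC)cc(NCc3cc(Cl)cc(NC(=O)OC(C)C)c3)n2)nc1C`: 5.5 nM

In an assay on cells for binding affinity to Neuropeptide Y receptor type 1 (Homo sapiens) (a higher number here means a weaker inhibitor, a lower number a stronger inhibitor), compound 1 gives the higher of the two numbers; compound 2 gives the lower, and the step of a 2.9-fold lower number from compound 1 to compound 2 (0.46 log units; beyond the scatter) is beyond the usual scatter. Compound 3, `CCc1sc(CCc2cc(OC3CCC3)cc(NCc3cc(Cl)cc(NC(=O)OC(C)C)c3)n2)nc1C`, is not yet measured. It differs from compound 1 in one place: cyclobutyl in place of butyl on an oxygen on an aromatic ring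

For the measured compounds named here, the only measured step that bears on this position is the one from compound 1 to compound 2, in which a branched group replaced the straight chain on the same oxygen and the number fell modestly. Cyclobutyl also carries its attachment on a carbon that is part of a larger unit rather than at the end of a chain, so a change of the same sign is plausible, but no measured compound shows a ring at this place, and the step could equally stay within the scatter. Compound 3 is therefore expected to give 10 nM, with a range of 4 nM to 25 nM. This expectation corresponds to a step of a 1.6-fold lower number from compound 1 to compound 3 (0.20 log units; within the scatter).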

Compound 3, half-maximal inhibitory concentration: 11 nM
Estimate against measurement, compound 3: 1.1-fold (0.04 log units) below, within the range that was stated.
By their numbers in this assay, from the lowest: compounds 2, 3 and 1 (each within the scatter of the next, the first and the last beyond it).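

Placing a ring on this oxygen, with cyclobutyl in place of butyl, gives a 1.5-fold lower number from compound 1 to compound 3 (0.16 log units; within the scatter) in this assay, so in this assay the ring cannot be told apart from the straight chain of the same four carbons. Cyclobutyl in place of pentan-3-yl gives a 2.0-fold higher number from compound 2 to compound 3 (0.30 log units; within the scatter), so it cannot be told apart from the branched group either, even though the earlier step between the two open-chain groups, a 2.9-fold lower number from compound 1 to compound 2 (0.46 log units; beyond the scatter), lies beyond the scatter. Compound 3 therefore sits within the scatter of both neighbours, and the three ethers do not show whether a ring at this place behaves more like the butyl or the pentan-3-yl group, while nothing on hand accounts for any of these numbers.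

The compounds shown leave open how other rings on the same oxygen, such as cyclopropyl, cyclopentyl or cyclohexyl, would read in this assay. They also leave open what a chain carrying an ether oxygen or an amine at this place would do, and whether a repeat of these measurements would separate cyclobutyl from its two neighbours.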